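This account rests on a few compounds, and the source may have more. Where it says the series, first, only, none or still open, it means among the compounds named here.

Measured so far: compound 1 `Cc1cccc(C)c1-c1cccc(COc2ccc(CCC(=O)O)s2)c1` with 32 nM in a functional assay on cells for agonist activity at Free fatty acid receptor 1 (Homo sapiens), read by calcium flux (a lower number here means that less compound is needed, a higher number that more compound is needed for the effect), and compound 2 `COc1ccc(F)c(-c2cccc(COc3ccc(CCC(=O)O)s3)c2)c1` with 580 nM in the same assay.

Compound 2 stands at the higher of the two numbers, so more of it is needed than of compound 1. Going by the values given here, the only step measured so far is an 18-fold higher number from compound 1 to compound 2 (1.26 log units; beyond the scatter), a large change that comes from exchanging one aromatic side group for another on the shared core.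

Compound 3 `O=C(O)CCc1ccc(OCc2cccc(-c3ccncc3Cl)c2)s1` has not yet been measured. It differs from compound 2 by 3-chloropyridin-4-yl in place of 2-fluoro-5-methoxyphenyl on an aromatic carbon. Among the compounds with values here, the measured step does not test this exchange directly; it shows only that the side group at this place moves the number strongly, and that a group with two methyl substituents gave the lower number. Going by these compounds, a ring with one hetero atom and a chlorine is new here, so the direction of the step from compound 2 remains open.

The expectation for compound 3 is a moderate step, a 2.3-fold lower number from compound 2 to compound 3 (0.37 log units; beyond the scatter), with a wide range. The estimated value for compound 3 is 250 nM, between 60 nM and 1200 nM.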

Compound 3, half-maximal effective concentration: 2010 nM
Estimate against measurement, compound 3: 8.0-fold (0.91 log units) below, outside the stated range (above it).
By their numbers in this assay, from the lowest: compound 1; then compound 2; then compound 3.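

In this assay, the exchange of 2-fluoro-5-methoxyphenyl for 3-chloropyridin-4-yl gives a 3.5-fold higher number from compound 2 to compound 3 (0.54 log units; beyond the scatter), which shows that compound 2 did not mark the upper end of what this position can give and that this first ring with a hetero atom calls for still more compound. Measured against the 2,6-dimethylphenyl group, the same ring gives a 63-fold higher number from compound 1 to compound 3 (1.80 log units; beyond the scatter), so this one position now spans a wider range than the earlier pair showed, and among these three side groups 2,6-dimethylphenyl still needs the least compound. Nothing measured here explains why the number rises at this position.

Because the ring nitrogen, the chlorine and the other substituents all change together in this exchange, the compounds shown leave open which of them accounts for the step, and a pyridine ring with a methyl group in place of the chlorine, or a phenyl ring carrying chlorine alone, would pull these apart. Going by these compounds, it also remains open whether an amine on this ring would bring the number down or push it up further.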